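A few compounds are considered here, and "the series" means these few. Any claim that something is new, unique, unknown or untested is made for them only; others in the source may bear on it.

Measured so far in an assay for inhibition of Amine oxidase [flavin-containing] B (Rattus norvegicus); on this read-out lower numbers stand for stronger inhibition and higher numbers for weaker inhibition:
compound 1 `C[C@H](Nc1cc(=O)oc2cc(OCc3ccccc3)ccc12)C(N)=O` — 680 nM
compound 2 `C[C@H](Nc1cc(=O)oc2cc(OCc3cccc(Cl)c3)ccc12)C(N)=O` — 210 nM
compound 3 `NC(=O)[C@H](CO)Nc1cc(=O)oc2cc(OCc3cccc(Cl)c3)ccc12` — 2400 nM

Compound 3 stands at the highest number of the three, with compound 2 well below it, as an 11-fold higher number from compound 2 to compound 3 (1.06 log units; beyond the scatter) shows, and compound 1 also at a lower number. Compound 4 `NNC(=O)Cc1cc(=O)oc2cc(OCc3cccc(Cl)c3)ccc12` has not yet been measured. It differs from compound 3 in one place: (aminocarbamoyl)methyl in place of (1-carbamoyl-2-hydroxyethyl)amino on an aromatic carbon. Of the measured steps, a 3.2-fold lower number from compound 1 to compound 2 (0.51 log units; beyond the scatter) concerns the chloro on the benzyl ring, which compounds 3 and 4 share, so it does not bear on this change. The step that does bear on it is an 11-fold higher number from compound 2 to compound 3 (1.06 log units; beyond the scatter), since the hydroxy that raised the number there leaves in compound 4. The group that enters is not the group of compound 2, however, so the step is unlikely to be a plain reversal, and the uncertainty is wide. A modest drop is expected: the step from compound 3 to compound 4 is estimated at a 2.7-fold lower number from compound 3 to compound 4 (0.43 log units; beyond the scatter). For compound 4 the estimate in this assay is 900 nM, within a range of 180 nM to 4500 nM.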

Compound 4, half-maximal inhibitory concentration: 90 nM
For compound 4 the middle estimate is 10-fold (1.00 log units) above the measured one; measured number below the stated range.
By their numbers in this assay, from the lowest: compound 4; then compound 2; then compound 1; then compound 3.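

On the carbon opposite the ring oxygen, in this assay, replacing (1-carbamoyl-2-hydroxyethyl)amino with (aminocarbamoyl)methyl gives a large gain (a 27-fold lower number from compound 3 to compound 4 (1.43 log units; beyond the scatter)). The new group also outperforms the (1-carbamoylethyl)amino group, though more modestly (a 2.3-fold lower number from compound 2 to compound 4 (0.37 log units; beyond the scatter)), so this position does not need a nitrogen attached directly to the aromatic carbon for the number to fall, and compound 4 has the lowest number of the four. Nothing reported here gives a reason for this gain.

The change alters the linking atom, the chain and the terminal group at once, so these compounds cannot show which of them accounts for the steps. Going by these compounds, it remains open how a carboxylic acid or a longer chain ending in the same hydrazide would fare at this position, and whether the gain from chloro on the benzyl ring also holds with the new group.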